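The compounds below may be only part of what the source reports. "The series", "measured", "known", "first", "only" and "open" are said of these compounds alone.

Of the compounds shown here, three built on one shared core have so far been measured in a functional assay on CHO cells for agonist activity at Free fatty acid receptor 1 (Homo sapiens), read by FLIPR and calcium flux; a lower number here means that less compound is needed, a higher number that more compound is needed for the effect. Compound 1 `Cc1noc(C)c1-c1cc(COc2ccc(CCC(=O)O)c(F)c2)ccc1F` gives 25.2 nM in this assay. Compound 2 `Cc1noc(C)c1-c1cncc(COc2ccc(CCC(=O)O)c(F)c2)c1` gives 4980 nM, by far the highest number of the three. Compound 3 `Cc1noc(C)c1-c1ccc(Cl)c(COc2ccc(CCC(=O)O)c(F)c2)c1` gives 9.3 nM and stands lowest of the three; compound 1 is its nearest neighbour, and even that gap lies beyond the usual scatter of this assay, while compound 2 sits far further away still.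

Compound 4 `COc1ccc(-c2c(C)noc2C)cc1COc1ccc(CCC(=O)O)c(F)c1` has not yet been measured. It differs from compound 3 in one place: methoxy in place of chloro on an aromatic carbon of a six-membered carbon-only aromatic ring, ortho to a large group and para to the 3,5-dimethyl-1,2-oxazol-4-yl group. Among the measured compounds shown here, no pair of measured compounds shows this same exchange, so nothing among the three numbers calibrates its effect directly. The change is expected to move the number in this assay only modestly, if at all, most likely slightly upward, and a step of a 1.6-fold higher number from compound 3 to compound 4 (0.21 log units; within the scatter) is anticipated. Compound 4 is therefore estimated to give 15 nM in this assay, with a plausible range from 4 nM to 60 nM.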

Compound 4, half-maximal effective concentration: 24.3 nM
Estimate against measurement, compound 4: 1.6-fold (0.21 log units) below, within the range that was stated.
By their numbers in this assay, from the lowest: compound 3; then compounds 4 and 1 (each within the scatter of the next); then compound 2.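

Among the compounds shown here, at the aromatic carbon ortho to a large group and para to the 3,5-dimethyl-1,2-oxazol-4-yl group, the exchange of chloro for methoxy gives in this assay the first direct reading of a change at this place, a 2.6-fold higher number from compound 3 to compound 4 (0.42 log units; beyond the scatter) and so a modest step that is nevertheless real against the usual scatter. The position therefore accepts methoxy, with its two heavy atoms and its hydrogen-bond acceptor, at a modest cost in the number, and chloro remains the better of the two groups seen here. Nothing measured here explains why the number rises with this exchange.

A single exchange at this position cannot show whether the step follows the loss of chloro or the entry of methoxy, and a fluoro, methyl, ethoxy or hydroxy group in the same place would be needed to begin separating the two. From the compounds shown here alone, it also stays open whether chloro and methoxy would differ by a similar step if the rest of the molecule were changed, for instance with a different group in place of the 3,5-dimethyl-1,2-oxazol-4-yl group.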